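One hydroxy group added to compound 3

The compounds below may be only part of what the source reports. "The series", "measured", "known", "first", "only" and "open" are said of these compounds alone.

Three related compounds have been read so far in a physicochemical assay for solubility, read by nephelometry, measured as kinetic solubility, with a stated time of 30 min, at pH 2.0 (on this read-out lower numbers stand for lower solubility and higher numbers for higher solubility), and they frame the question. Compound 1 `CC(=O)NC1C2CC3CC1CC(C2)C31OO[C@]2(CC[C@@H](c3ccc(OCC(=O)O)cc3)CC2)O1` gives 12.5 ug/mL there, and compound 2 `O=C(O)COc1ccc([C@H]2CC[C@]3(CC2)OOC2(O3)C3CC4CC2CC(C3)C4=O)cc1` gives 50 ug/mL there. Compound 3 `O=C(O)c1cccc([C@H]2CC[C@]3(CC2)OOC2(O3)C3CC4CC(C3)CC2C4)c1` gives < 1.6 ug/mL as a limit of the assay and not a number.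

Compound 4 `O=C(O)c1cc([C@H]2CC[C@]3(CC2)OOC2(O3)C3CC4CC(C3)CC2C4)ccc1O` differs from compound 3 in a single place hydroxy in place of hydrogen on an aromatic carbon and this change puts hydroxy in place of hydrogen on an aromatic carbon, ortho to a carboxy group and para to a large group. No measured pair among these compounds shows this change on its own, so there is no direct precedent for its size. Within the data shown here, a small rise in this assay or no step beyond the scatter is expected, and the only anchor is compound 3 at the limit of < 1.6 ug/mL in this assay, at which 1 of the 3 values shown sits, in this set. The expected step is an at least 1.2-fold higher number from compound 3 to compound 4 (0.09 log units; that floor lies within the scatter) on this estimate. Compound 4 is estimated at 2 ug/mL with an expected range of 0.8 ug/mL to 6.25 ug/mL overall.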

Compound 4, solubility: > 100 ug/mL
Compound 4 was reported as a limit; the forecaster's own chance of this, stated with the estimate: 55%; middle value at least 50-fold (1.69 log units) away from the limit.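

Among these compounds, the pair gives the first single-change reading in this assay: hydroxy in place of hydrogen on an aromatic carbon, ortho to a carboxy group and para to a large group, goes with an at least 62-fold higher number from compound 3 to compound 4 (1.79 log units; beyond the scatter). Compound 3 gives < 1.6 ug/mL, which is a limit of the assay and not a number. From the compounds shown here alone, compound 4 gives > 100 ug/mL, again a limit and not a number, so the pair fixes only a floor for the step, and its true size stays unknown.

The compounds shown leave open whether an amine or a fluorine in the same place would go with a step of similar size. They also leave open whether hydroxy at another place on this aromatic ring, or on the other cores shown here, would go with a step of this size.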